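A few compounds are considered here, and "the series" means these few. Any claim that something is new, unique, unknown or untested is made for them only; others in the source may bear on it.

Compound 1 `C[C@@]12CCC(=O)[C@@](C)(CO)[C@H]1CCC(CO)=C2CCC1=CCOC1=O`: 79000 nM
Compound 2 `C=C1[C@H](O)C[C@H]2[C@@](C)(CCC(=O)[C@@]2(C)CO)[C@@H]1CCC1=CCOC1=O`: 58300 nM

Both compounds were tested in a functional assay on RAW264.7 cells (Mus musculus) for inhibition, read by Griess assay, with a stated time of 24 h; on this read-out lower numbers stand for stronger inhibition and higher numbers for weaker inhibition. The values of compound 2 and compound 1 lie within the usual scatter of each other, so compound 2 stands level with compound 1 and neither can be ranked ahead.

Compound 3 `C=C1CC[C@H]2[C@@](C)(CCC(=O)[C@@]2(C)CO)[C@@H]1CCC1=CCOC1=O` departs from compound 2 at one place: hydrogen in place of hydroxy on a saturated ring carbon. This puts hydrogen in place of hydroxy on a saturated ring carbon. Going by the values given here, no measured pair in this small set shows what such a change does, so the only anchor is compound 2 at 58300 nM. On that basis, no step beyond the scatter is expected in this assay, in either direction.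

The estimated step of a 1.1-fold lower number from compound 2 to compound 3 (0.03 log units; within the scatter) therefore stays small. For compound 3 the expected value is 55000 nM, with an estimated range of 22000 nM to 120000 nM.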

Compound 3, half-maximal inhibitory concentration: 10100 nM
Beside the measured number, compound 3's estimate is 5.4-fold (0.74 log units) above it, outside the stated range (below it).
By their numbers in this assay, from the lowest: compound 3; then compounds 2 and 1 (each within the scatter of the next).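

In this assay, going by these compounds alone, the step is a 5.8-fold lower number from compound 2 to compound 3 (0.76 log units; beyond the scatter) when hydrogen takes the place of hydroxy on this saturated ring carbon, and it is the only step in the set that can be read beyond the scatter. The hydroxy at this place is therefore not needed for the inhibition read here, since compound 3, which lacks it, gives the lower number of this pair. Nothing available on these compounds accounts for the size of this step.

The compounds shown leave open what a methoxy group, an amine or a fluorine atom would do on this same ring carbon, and whether the hydroxy with the opposite orientation would behave like the one in compound 2. On these data alone, it also remains open whether removing a hydroxy elsewhere on the shared core would give a step of similar size.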